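The source may hold more compounds than are shown below. What is called first, only, known or untested is meant among the compounds shown, and "the series" means these compounds.

In a functional assay on CCRF-SB cells (Homo sapiens) for cytotoxicity, read by MTT assay, with a stated time of 96 h (on this read-out lower numbers stand for higher toxicity in this test and higher numbers for lower toxicity in this test), three compounds sharing one core have been measured. Compound 1 `FC(F)(F)c1cccc(NC(=S)Nc2ccc(I)cc2)c1` gives 9100 nM, compound 2 `FC(F)(F)c1cccc(NC(=S)Nc2ccc(Cl)cc2)c1` gives 11000 nM and compound 3 `N#Cc1ccc(NC(=S)Nc2cccc(C(F)(F)F)c2)cc1` gives 8300 nM. Compound 2 therefore stands with the other two, and the usual scatter of this kind of measurement leaves them no real ranking.

The next compound is compound 4 `FC(F)(F)c1cccc(NC(=S)Nc2cccc(Br)c2)c1`, which differs from compound 2 as follows: 3-bromophenyl in place of 4-chlorophenyl on an amide-type nitrogen. In this change, 3-bromophenyl takes the place of 4-chlorophenyl on an amide-type nitrogen.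

The measured steps that bear on it swap one group on that same aromatic ring: a 1.2-fold higher number from compound 1 to compound 2 (0.08 log units; within the scatter), a 1.1-fold lower number from compound 1 to compound 3 (0.04 log units; within the scatter) and a 1.3-fold lower number from compound 2 to compound 3 (0.12 log units; within the scatter). All three stay within the scatter, so swapping the group has shown little effect so far. For the measured compounds named here, no measured compound has a 3-substituted ring here, so that part of the change is untested and the range must stay wide.

The expected step is small, a 1.2-fold lower number from compound 2 to compound 4 (0.09 log units; within the scatter), and no change beyond the scatter is expected. Compound 4 is estimated at 9000 nM, with an expected range of 4000 nM to 20000 nM.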

Compound 4, half-maximal cytotoxic concentration: 9000 nM
The estimate for compound 4 equals the measured number at the digits printed; low and high end bracket the measured number.
By their numbers in this assay, from the lowest: compounds 3, 4, 1 and 2 (each within the scatter of the next).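

In this assay, the change to 3-bromophenyl gives a 1.2-fold lower number from compound 2 to compound 4 (0.09 log units; within the scatter) and a 1.0-fold lower number from compound 1 to compound 4 (0.00 log units; within the scatter), and both steps stay within the scatter. The earlier steps shown here only swapped one group for another, whereas these two change the group and also where it sits on the ring, and the number still does not move beyond the scatter. Each step changes both at once, so the data cannot separate the two changes, and nothing measured here gives a reason for this flat result.

Going by these compounds, it remains open whether the picture would hold for a ring carrying an amine or a carboxylic acid instead of the halogens and the cyano group seen so far. The trifluoromethyl-bearing ring is the same in all four compounds, so the effect of a change there is also unknown.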